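A few compounds are considered here, and "the series" means these few. Any claim that something is new, unique, unknown or untested is made for them only; others in the source may bear on it.

Measured so far in an ADME assay on BJ cells (Homo sapiens) for cytotoxicity, with a stated time of 72 h; a lower number here means that less compound is needed, a higher number that more compound is needed for the effect:
Compound 1, `COC(=O)c1ccc(NC(=O)Nc2cc(C)nc3ccccc23)cc1`, gives 21000 nM.
Compound 2, `Cc1cc(NC(=O)Nc2ccc(C(C)(C)C)cc2)c2ccccc2n1`, gives 20000 nM.

Compound 2 holds the lower of the two numbers, but only just: a 1.1-fold lower number from compound 1 to compound 2 (0.02 log units; within the scatter), so the two compounds cannot be told apart on these data. Compound 3, `Cc1cc(NC(=O)Nc2ccc(OC(F)(F)F)cc2)c2ccccc2n1`, is not yet measured. Compared with compound 2 it differs in one place: trifluoromethoxy in place of tert-butyl on an aromatic carbon. For the measured compounds named here, the only measured step that bears on this is a 1.1-fold lower number from compound 1 to compound 2 (0.02 log units; within the scatter), which also exchanged one group for another on an aromatic carbon and stayed within the scatter. On that single example, the trifluoromethoxy group in compound 3 is expected to leave this assay largely unchanged, with no step beyond the scatter in either direction. Compound 3 is therefore estimated at 20000 nM, within a range of 8000 nM to 50000 nM, which corresponds to an expected step of no change at the digits printed from compound 2 to compound 3 (within the scatter).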

Compound 3, half-maximal effective concentration in the BJ assay: 25000 nM
The estimate for compound 3 lay 1.3-fold (0.10 log units) below the measured number, and the stated range covers the measured number.
By their numbers in the BJ assay, from the lowest: compounds 2, 1 and 3 (each within the scatter of the next).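

In the BJ assay, this place on the aromatic ring has now carried three different groups with no step beyond the scatter, as trifluoromethoxy gives a 1.3-fold higher number from compound 2 to compound 3 (0.10 log units; within the scatter) and a 1.2-fold higher number from compound 1 to compound 3 (0.08 log units; within the scatter). A different picture appears in a physicochemical assay for solubility, at pH 7.4 (on this read-out lower numbers stand for lower solubility and higher numbers for higher solubility), where compound 2 gives 6200 nM and compound 3 gives 300 nM. The position is therefore far from silent: the exchange that the BJ assay does not register lowers solubility sharply, and this shows only when the BJ assay is set beside the physicochemical assay: the measured solubility of compound 2, 6200 nM, and of compound 3, 300 nM, a 21-fold lower number (1.32 log units; beyond the scatter)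

Where compound 1, with its methoxycarbonyl group, would fall in the physicochemical assay remains open. So does whether a group of another kind at this place, such as an amine or a carboxylic acid, would keep the BJ assay as flat or would restore solubility.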